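Solubility of a piperidine carboxamide with a piperazinyl urea

The compounds below may be only part of what the source reports. "The series", "measured", "known", "first", "only" and "open" are said of these compounds alone.

Compound 1 `CC(C)CN1CCCC[C@H]1C(=O)Nc1cc(C(C)(C)C)on1`: in a physicochemical assay for solubility, read by HPLC, at pH 6.8 (on this read-out lower numbers stand for lower solubility and higher numbers for higher solubility), compound 1 gives 32 ug/mL
Compound 2 `CC(C)(C)c1cc(NC(=O)[C@@H]2CCCCN2C2CCOCC2)no1`: in this assay compound 2 gives 74 ug/mL
Compound 3 `CC(C)(C)c1cc(NC(=O)[C@@H]2CCCCN2C(=O)C2CCOCC2)no1`: in this assay compound 3 gives 48 ug/mL

Compound 3 stands second highest of the three numbers. Its nearest neighbour is compound 1, with a 1.5-fold higher number from compound 1 to compound 3 (0.18 log units; within the scatter), and the remaining gap is a 1.5-fold lower number from compound 2 to compound 3 (0.19 log units; within the scatter); both lie within the scatter. Going by the values given here, the only step beyond the scatter is a 2.3-fold higher number from compound 1 to compound 2 (0.36 log units; beyond the scatter), which concerns the amine nitrogen in the ring rather than the carbonyl carbon.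

Compound 4 `CCC(=O)N1CCN(C(=O)N2CCCC[C@H]2C(=O)Nc2cc(C(C)(C)C)on2)CC1` differs from compound 3 in one place: 4-propanoylpiperazin-1-yl in place of oxan-4-yl on a carbonyl carbon. Among the compounds with values here, no measured step replaces a group on this carbonyl carbon, so the steps above bear on it only indirectly. All three measured numbers sit in a narrow band, and the two steps that end at compound 3 are within the scatter. The expectation for compound 4 is therefore a step of a 1.3-fold higher number from compound 3 to compound 4 (0.10 log units; within the scatter) in this assay, not clearly beyond the scatter. Compound 4 is estimated at 60 ug/mL, with a range from 25 ug/mL to 140 ug/mL.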

Compound 4, solubility: 68 ug/mL
For compound 4 the middle estimate is 1.1-fold (0.05 log units) below the measured one; the range from low to high includes it.
By their numbers in this assay, from the lowest: compounds 1, 3, 4 and 2 (each within the scatter of the next, the first and the last beyond it).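

Going by these compounds alone, the step on this carbonyl carbon, whose other neighbour is an amide-type nitrogen in a ring, is the first measured replacement at this place. In this assay the move from oxan-4-yl to 4-propanoylpiperazin-1-yl gives a 1.4-fold higher number from compound 3 to compound 4 (0.15 log units; within the scatter) and so stays inside the usual scatter, even though the entering group has 10 heavy atoms against 6 and brings 2 ring hetero atoms in place of 1. No measurement at hand accounts for this result.

Still open, going by these compounds, is whether a carboxylic acid or an amine at the end of a longer chain on this carbonyl carbon would carry the number beyond the scatter. The compounds shown also leave open how a plain piperazin-1-yl, without the propanoyl, would read at the same place.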